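The source may hold more compounds than are shown below. What is called first, only, known or untested is meant among the compounds shown, and "the series" means these compounds.

Among the three compounds measured so far, compound 2 `O=C(COc1cccc2ccccc12)N/N=C/c1ccccc1Cl` gives the highest number in an ADME assay on HEL cells (Homo sapiens) for cytotoxicity (on this read-out lower numbers stand for higher toxicity in this test and higher numbers for lower toxicity in this test), with 62.7 ug/mL. Compound 3 `C/C(=N\NC(=O)COc1cccc2ccccc12)c1ccc(Br)cc1` gives 15.3 ug/mL in this assay, and compound 1 `C/C(=N\NC(=O)COc1cccc2ccccc12)c1ccc(O)cc1` gives 11.1 ug/mL. Among the compounds with values here, the one measured step, a 1.4-fold higher number from compound 1 to compound 3 (0.14 log units; within the scatter), exchanges one group on an aromatic ring and stays within the scatter. Compound 4 `O=C(COc1cccc2ccccc12)N/N=C/c1ccc(F)cc1` differs from compound 2 in one place: 4-fluorophenyl in place of 2-chlorophenyl on a carbon with a double bond to nitrogen. Within the data shown here, no measured step exchanges one halophenyl for another, so that single within-scatter step is the only guide, and a small step is expected, a 1.4-fold lower number from compound 2 to compound 4 (0.14 log units; within the scatter), leaning lower because compound 2 already stands highest at 62.7 ug/mL. For compound 4 the estimate is 45 ug/mL, with a range from 20 ug/mL to 95 ug/mL.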

Compound 4, half-maximal cytotoxic concentration: 71.6 ug/mL
The estimate for compound 4 lay 1.6-fold (0.20 log units) below the measured number; the range from low to high includes it.
By their numbers in this assay, from the lowest: compounds 1 and 3 (each within the scatter of the next); then compounds 2 and 4 (each within the scatter of the next).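

The step of a 1.1-fold higher number from compound 2 to compound 4 (0.06 log units; within the scatter) in this assay comes from exchanging 2-chlorophenyl for 4-fluorophenyl on a carbon with a double bond to nitrogen. It shows that these two halophenyl groups cannot be told apart at this place in this test, although the halogen and its place on the ring change together, so neither change can be judged alone. Nothing available explains this result. On these data alone, whether a phenyl ring carrying an amine or a carboxylic acid would also stay within the scatter remains open. So does what separates compounds 2 and 4 from compounds 1 and 3, which differ from them in more than one place.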